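The compounds below may be only part of what the source reports. "The series", "measured", "known", "first", "only" and "open" are said of these compounds alone.

Compound 2 `O=C(NO)c1ccc(NCc2nc(-c3ccccc3Cl)nn2-c2ccccc2)cc1` is an inhibitor measured in an assay on Sf9 cells for inhibition of protein deacetylase HDAC6 (Homo sapiens), read by fluorescence, with a stated time of 40 min; on this read-out lower numbers stand for stronger inhibition and higher numbers for weaker inhibition. In this assay, within the data shown here, compound 2 gives 185 nM, and the only other measured compound, compound 1 `COc1ccc(-c2nc(CNc3ccc(C(=O)NO)cc3)n(-c3ccccc3)n2)cc1`, gives 163 nM, so the two numbers lie within the usual scatter of each other. Among the measured compounds shown here, the single measured step, a 1.1-fold higher number from compound 1 to compound 2 (0.05 log units; within the scatter), exchanged one aromatic group at the same position without a real change in the number. Compound 3 `Cc1ccc(-c2nc(CNc3ccc(C(=O)NO)cc3)n(-c3ccccc3)n2)s1` differs from compound 2 as follows: 5-methylthiophen-2-yl in place of 2-chlorophenyl on an aromatic carbon. Since this is again an exchange of the aromatic group at that position, the expected step is a 1.0-fold lower number from compound 2 to compound 3 (0.01 log units; within the scatter), nothing beyond the scatter. Compound 3 is therefore estimated at 180 nM, with a likely range from 90 nM to 360 nM.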

Compound 3, half-maximal inhibitory concentration: 30.6 nM
Beside the measured number, compound 3's estimate is 5.9-fold (0.77 log units) above it; measured number below the stated range.
By their numbers in this assay, from the lowest: compound 3; then compounds 1 and 2 (each within the scatter of the next).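

In this assay the group at this position can clearly shift the number, which the exchange between the two substituted phenyl groups did not show. Putting 5-methylthiophen-2-yl in place of 2-chlorophenyl gives a 6.0-fold lower number from compound 2 to compound 3 (0.78 log units; beyond the scatter) and putting it in place of 4-methoxyphenyl gives a 5.3-fold lower number from compound 1 to compound 3 (0.73 log units; beyond the scatter) with both steps ending at the same compound. Nothing available explains this gain. Still open, on these data alone, is whether the gain follows from the thiophene ring or its methyl group, and whether an unsubstituted thiophene, a furan or a pyridine would match it.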